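Swapping the aryl group of a benzyl ether GPR39 agonist

The source may hold more compounds than are shown below. What is called first, only, known or untested is meant among the compounds shown, and "the series" means these compounds.

Measured compounds:
compound 1, `Cc1nn(-c2ncnc3nc[nH]c23)c2c1C(C(=O)Nc1ccccc1)CC(=O)N2`: 10 nM
compound 2, `Cc1nn(-c2ncnc3nc[nH]c23)c2c1C(OCc1ccccc1F)CC(=O)N2`: 4 nM

In a functional assay on HEK293 cells for agonist activity at G-protein coupled receptor 39 (Homo sapiens), read by scintillation proximity assay and inositol phosphate accumulation, with a stated time of 75 min, in the presence of a further agent that is not named here (a lower number here means that less compound is needed, a higher number that more compound is needed for the effect), compound 1 gives 10 nM, and compound 2 gives 4 nM. Compound 2 therefore has the lower of the two numbers, the gap to compound 1 lying beyond the scatter. For the measured compounds named here, the single measured step, a 2.5-fold lower number from compound 1 to compound 2 (0.40 log units; beyond the scatter), exchanges phenylcarbamoyl for (2-fluorobenzyl)oxy on a saturated ring carbon, a change of the whole side chain rather than of the aromatic ring within it.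

Compound 3, `Cc1nn(-c2ncnc3nc[nH]c23)c2c1C(OCc1ccc(C(C)C)cc1)CC(=O)N2`, differs from compound 2 by 4-isopropylphenyl in place of 2-fluorophenyl on a saturated chain carbon bound to an oxygen on a saturated carbon. Going by the values given here, no measured step alters the aromatic ring of the benzyl ether while keeping the ether linkage, so the data give no direct guide to this change; the only step on record concerns a different part of the molecule. With that in mind, compound 3 is expected to come out near compound 2, at an estimated 6 nM, within a broad range from 1.5 nM to 25 nM. The estimated step of a 1.5-fold higher number from compound 2 to compound 3 (0.18 log units; within the scatter) is expected to stay within the scatter, in no firm direction.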

Compound 3, half-maximal effective concentration: 5 nM
Compound 3: middle estimate off by 1.2-fold (0.08 log units), on the high side; the range from low to high includes it.
By their numbers in this assay, from the lowest: compounds 2, 3 and 1 (each within the scatter of the next, the first and the last beyond it).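

In this assay, the change from 2-fluorophenyl to 4-isopropylphenyl gives a 1.3-fold higher number from compound 2 to compound 3 (0.10 log units; within the scatter), and this is the first step shown that alters the aromatic ring while keeping the ether linkage. It shows that, for this pair, the position can hold a group of 9 heavy atoms, all carbon, instead of one of 7 heavy atoms that includes a fluorine, with the number staying within the scatter, so the fluorine of compound 2 is not needed to keep the number at this level. Nothing measured here explains why the two compounds read alike.

On these data alone, a single pair sets no rule for this position, so it remains open whether the number would also hold with a carboxylic acid or an amine on the aromatic ring, or with a pyridine ring in place of the benzene ring. As far as these compounds go, it is equally open what a longer chain between the ether oxygen and the ring would do, since both compounds carry a benzyl group there.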